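Triazole substituent: sulfonamide replaced by tolyl group

A few compounds are considered here, and "the series" means these few. Any claim that something is new, unique, unknown or untested is made for them only; others in the source may bear on it.

Measured so far:
Compound 1, `CCCCCCCCCCc1cn(C[C@H](O)[C@H]2OC(=O)C(OCc3ccccc3)=C2OCc2ccccc2)nn1`, in a functional assay on MCF7 cells (Homo sapiens) for antiproliferative activity, read by MTT assay, with a stated time of 72 h (a lower number here means a stronger inhibitor, a higher number a weaker inhibitor), gives 80 nM.
Compound 2, `O=C1O[C@H]([C@@H](O)Cn2cc(CNS(=O)(=O)c3ccc(Cl)cc3)nn2)C(OCc2ccccc2)=C1OCc1ccccc1`, in this assay gives 4170 nM.

Compound 2 stands at the higher of the two numbers on record. For the measured compounds named here, the single measured step in this assay is a 52-fold higher number from compound 1 to compound 2 (1.72 log units; beyond the scatter), in which the nonyl chain on the triazole was exchanged for the sulfonamide-bearing group, with a large loss beyond the scatter.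

Compound 3, `Cc1ccc(-c2cn(C[C@H](O)[C@H]3OC(=O)C(OCc4ccccc4)=C3OCc3ccccc3)nn2)cc1`, differs from compound 2 by 4-methylphenyl in place of (((4-chlorophenyl)sulfonyl)amino)methyl on an aromatic carbon. The step that bears on it is a 52-fold higher number from compound 1 to compound 2 (1.72 log units; beyond the scatter): the present change takes out the sulfonamide group that arrived in that step and puts an aryl substituent directly on the triazole carbon. A partial reversal of the earlier loss is therefore expected in this assay, a lower number for compound 3 than for compound 2, beyond the scatter but short of the full extent of that step, since 4-methylphenyl is not the nonyl chain of compound 1. The expected step is a 7.0-fold lower number from compound 2 to compound 3 (0.84 log units; beyond the scatter). Compound 3 is estimated at 600 nM, within a range from 150 nM to 3000 nM.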

Compound 3, half-maximal inhibitory concentration: > 100000 nM
Compound 3 gave a limit, no number (the forecaster's own chance of this, stated with the estimate: 5%); middle value at least 160-fold (2.22 log units) away from the limit.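

In this assay, compound 3 gives a limit and not a number: the limit of > 100000 nM in this assay, at which 1 of the 3 values shown sits.

Both steps into compound 3 are large and beyond the scatter, an at least 23-fold higher number from compound 2 to compound 3 (1.37 log units; beyond the scatter), and an at least 1200-fold higher number from compound 1 to compound 3 (3.09 log units; beyond the scatter). At this aromatic carbon of the five-membered ring with 3 nitrogen, removing the sulfonamide-bearing group therefore does not return the number towards that of compound 1, so the earlier loss, a 52-fold higher number from compound 1 to compound 2 (1.72 log units; beyond the scatter), cannot be assigned to that group alone, and 4-methylphenyl set directly on the ring carbon is the least active of the three substituents shown.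

The compounds shown leave open whether the low number of compound 1 depends on a long saturated chain as such, which a shorter chain, a longer chain or a benzyl group at the same carbon would test. Also open, from the compounds shown here alone, is how an amine or a carboxylic acid at the end of such a chain would read in this assay, and these three compounds give no cause for the differences.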